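One Ring Swap, One Clearance Expectation

The compounds below may be only part of what the source reports. "The series", "measured", "known", "first", "only" and "open" are said of these compounds alone.

Of the compounds shown here, three sharing one core have been tested in an ADME assay on cells (Hepatocyte, Rattus norvegicus) for metabolic stability, using equilibrium dialysis; on this read-out lower numbers stand for slow clearance and higher numbers for fast clearance. Compound 2 `CC(=O)N[C@@H]1CCC[C@H](C(=O)Nc2cc(-c3cnn4c3CCCC4)c(Cl)cn2)C1` gives 46 uL/min, the highest of the three numbers. Compound 3 `CC(=O)N[C@@H]1CCC[C@H](C(=O)Nc2cc(-c3cnn4c3CC(C)(C)CC4)c(F)cn2)C1` gives 42 uL/min, which sits within the scatter of compound 2, so no order between them can be claimed. Compound 1 `CC(=O)N[C@@H]1CCC[C@H](C(=O)Nc2cc(-c3cnc(C)n3C(C)C)ccn2)C1` gives 7.4 uL/min, well below compound 2 and beyond the scatter. Compound 4 `CC(=O)N[C@@H]1CCC[C@H](C(=O)Nc2cc(-c3cnc4n3CC(C)(C)C4)c(Cl)cn2)C1` has not yet been measured. It differs from compound 2 by a group of 10 heavy atoms (8 carbon, 2 nitrogen; one five-membered non-aromatic ring with 1 hetero atom, one five-membered aromatic ring with 2 hetero atoms) in place of a group of 9 heavy atoms (7 carbon, 2 nitrogen; one five-membered aromatic ring with 2 hetero atoms, one six-membered non-aromatic ring with 1 hetero atom), on an aromatic carbon. For the measured compounds named here, no measured pair shows this change, so there is no earlier step to lean on. For compound 4 the expected step is a 1.3-fold lower number from compound 2 to compound 4 (0.12 log units; within the scatter), which stays within the usual scatter. Compound 4 is therefore estimated at 35 uL/min, with a range from 15 uL/min to 80 uL/min.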

Compound 4, intrinsic clearance in a liver preparation (reported as CLH), per the amount of preparation that the assay uses: 28 uL/min
For compound 4 the middle estimate is 1.3-fold (0.10 log units) above the measured one; low and high end bracket the measured number.
By their numbers in this assay, from the lowest: compound 1; then compounds 4, 3 and 2 (each within the scatter of the next).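

In this assay, putting a five-membered non-aromatic ring in place of a six-membered one, on the aromatic carbon opposite the ring nitrogen, gives a 1.6-fold lower number from compound 2 to compound 4 (0.22 log units; within the scatter). For the compounds shown here, this is the first direct test of a change at this position, and here the change in ring size and heavy-atom count leaves clearance within the usual scatter. Nothing measured here explains this result. Still open, from the compounds shown here alone, is whether a hydroxyl group or an amine on the five-membered non-aromatic ring would shift clearance beyond the scatter.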